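Removing a Hydroxy Group: From Compound 1 to Compound 4

The compounds below may be only part of what the source reports. "The series", "measured", "known", "first", "only" and "open" are said of these compounds alone.

Compound 1 `COc1ccc(/C=C/C(=O)Nc2nc3ccc(Cl)cc3s2)cc1O`: 320 umol/kg
Compound 2 `COc1ccc(C2CC(Nc3nc4ccccc4s3)=NN2C(C)=O)cc1O`: 259 umol/kg
Compound 3 `Cc1ccc2nc(NC(=O)/C=C/c3ccc(O)cc3)sc2c1`: 271 umol/kg

Of the compounds shown here, three have so far been measured in a functional assay on the whole organism (Hindlimb, strain albino) with Mus musculus as the target, in the maximal electroshock model, with a stated time of 0.5 h; on this read-out higher numbers stand for an effect only at larger amounts of compound and lower numbers for an effect already at smaller amounts. Compound 1 gives 320 umol/kg there, compound 2 gives 259 umol/kg and compound 3 gives 271 umol/kg. The three numbers lie close together: the gap from compound 1 to compound 3 and the gap from compound 1 to compound 2 both fall within the usual scatter of repeated measurements, so no order can be read among them. No pair of these compounds differs in a single place, so no measured step is available.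

Compound 4 `COc1ccc(/C=C/C(=O)Nc2nc3ccc(Cl)cc3s2)cc1` has not yet been measured. It differs from compound 1 in one place: hydrogen in place of hydroxy on an aromatic carbon. Within the data shown here, with no measured step of this kind among the three compounds, the size and direction of the change in this assay remain open; the expectation is for no step beyond the scatter. Compound 4 is therefore expected to give about 320 umol/kg in this assay, between 160 umol/kg and 640 umol/kg, which means an estimated step of no change at the digits printed from compound 1 to compound 4 (within the scatter).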

Compound 4, dose for half-maximal effect: 259 umol/kg
Compound 4: the middle estimate sits 1.2-fold (0.09 log units) above what was measured; the measured number falls inside the stated range.
By their numbers in this assay, from the lowest: compounds 2, 4, 3 and 1 (each within the scatter of the next).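

The first single-place step now stands in this assay: hydrogen in place of hydroxy on an aromatic carbon gives (a 1.2-fold lower number from compound 1 to compound 4 (0.09 log units; within the scatter)). At this position, ortho to a methoxy group and meta to a large group, the hydroxy group, with its hydrogen-bond donor and acceptor, can therefore leave without a change that can be read on this measure in the core of compound 1. No measured evidence bearing on this result is at hand.

The compounds shown leave open whether another group at this position, such as an amine or a carboxylic acid, would give a step beyond the scatter. They also leave open whether the same change would read alike on the other cores shown here.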